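The source may report more compounds than this note shows. Statements on the series, on what has been measured and on what is new or still open speak of the compounds shown alone.

Measured compounds:
compound 1, `CCCCNc1nc(N)nc2c1CCN(Cc1ccccc1)C2`, 0.4 uM
compound 2, `CCCCNc1nc(N)nc2c1CN(C(=O)c1ccccc1)CC2`, 1.4 uM
compound 3, `CCCCNc1nc(N)nc2c1CCN(C(=O)c1ccccc1)C2`, 0.8 uM

All three share one core and differ only in the group carried on the amine nitrogen in the ring. In an assay on HEK293 cells for agonist activity at Toll-like receptor 8 (Homo sapiens), read by a luciferase reporter, with a stated time of 6 h (a lower number here means that less compound is needed, a higher number that more compound is needed for the effect), compound 2 gives 1.4 uM, the highest of the three numbers; its nearest neighbour is compound 3, which is within the scatter of it, while compound 1 lies beyond the scatter below it.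

Among the compounds with values here, the only measured step that changes the group on that ring nitrogen is a 2.0-fold higher number from compound 1 to compound 3 (0.30 log units; within the scatter), and it stays within the scatter. Compound 4, `CCCCNc1nc(N)nc2c1CN(C(=O)CC)CC2`, is not yet measured. It differs from compound 2 by ethyl in place of phenyl on a carbonyl carbon. Within the data shown here, no measured pair shows this particular exchange of phenyl for ethyl on the carbonyl carbon, so there is no direct precedent; what the data do show is that exchanging the whole group on the ring nitrogen, from benzyl to benzoyl, moved the number only within the scatter.

On that basis compound 4 is expected to give 1.4 uM in this assay, with a range from 0.5 uM to 4 uM. The expected step is no change at the digits printed from compound 2 to compound 4 (within the scatter), which would be within the scatter.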

Compound 4, minimum effective concentration: 0.4 uM
Compound 4: the middle estimate sits 3.5-fold (0.54 log units) above what was measured; measured number outside the range, below it.
By their numbers in this assay, from the lowest: compounds 1, 4, 3 and 2 (each within the scatter of the next, the first and the last beyond it).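

In this assay, within the data shown here, the earlier compounds offered a single exchange on the ring nitrogen, a 2.0-fold higher number from compound 1 to compound 3 (0.30 log units; within the scatter) and that exchange stayed within the scatter, so they gave no sign that this read-out responds to the group carried there. The step of a 3.5-fold lower number from compound 2 to compound 4 (0.54 log units; beyond the scatter) is beyond the scatter, which shows that the group on the carbonyl carbon can move the number even when the carbonyl itself and the shared core stay the same. The direction matters as well: with phenyl gone and ethyl in its place, the number falls rather than rises, so in this pair the six-membered aromatic ring of carbon is not required at this place, and the change from benzoyl to propanoyl costs nothing in this assay.

Going by these compounds, it remains open whether a shorter group such as methyl, a longer chain such as butyl, or an amine on the carbonyl carbon would lower the number further, and whether the same exchange would act alike on the core of compound 3. Nothing in the data shown explains why the number falls with this exchange.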